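This account rests on a few compounds, and the source may have more. Where it says the series, first, only, none or still open, it means among the compounds named here.

Of the compounds shown here, three that share one core have been tested in a functional assay on the whole organism (artery, strain albino) with Rattus norvegicus as the target, with a stated time of 720 min, at a dose of 10 mg/kg by the oral route; on this read-out lower numbers stand for less inhibition and higher numbers for more inhibition at the one dose given (going by the name of the read-out). Compound 1, `CC1=C(C(=O)Nc2ccc(Br)cc2)C(c2ccc(Cl)cc2Cl)N=C(SCc2ccc(Cl)cc2)N1`, gives 25.8% in this assay. Compound 2, `CC1=C(C(=O)Nc2ccc(Br)cc2)C(c2ccc(Cl)cc2Cl)N=C(SCc2ccc(F)cc2)N1`, differs from compound 1 only by fluoro in place of chloro on an aromatic carbon, and compound 2 gives 27.3% in this assay. That change made a step of a number 1.5 percentage points higher from compound 1 to compound 2 (within the scatter).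

Compound 3, `COc1ccc(C2N=C(SCc3ccc(Cl)cc3)NC(C)=C2C(=O)Nc2ccc(Br)cc2)cc1`, differs from compound 1 by 4-methoxyphenyl in place of 2,4-dichlorophenyl on a saturated ring carbon, and compound 3 gives 23.7% in this assay. That change made a step of a number 2.1 percentage points lower from compound 1 to compound 3 (within the scatter). All three numbers lie close together, so none of them can be set apart from the others.

Compound 4, `COc1ccc(C2N=C(SCc3ccc(F)cc3)NC(C)=C2C(=O)Nc2ccc(Br)cc2)cc1`, has not yet been measured. It differs from compound 3 by fluoro in place of chloro on an aromatic carbon. Within the data shown here, this is the same change as the one from compound 1 to compound 2, made here on the core of compound 3 rather than on the core of compound 1; the two cores differ as described for compound 3 against compound 1.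

Since the earlier step from compound 1 to compound 2 amounted to a number 1.5 percentage points higher from compound 1 to compound 2 (within the scatter), a step of about the same size is expected from compound 3 to compound 4, namely a number 1.3 percentage points higher from compound 3 to compound 4 (within the scatter), with the scatter of this assay as the main uncertainty. On this basis compound 4 is estimated to give 25% in this assay, with a likely range from 15% to 36%.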

Compound 4, a percentage reported as inhibition, in the whole organism at one dose (the size of the read-out at that dose, not a potency): 19.1%
Compound 4: middle estimate off by 5.9 percentage points, on the high side, within the range that was stated.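

On the core of compound 3, fluoro in place of chloro gave a number 4.6 percentage points lower from compound 3 to compound 4 (within the scatter), and set beside the same change on the core of compound 1, the two steps show no real disagreement: the same change on two cores in this assay, a number 1.5 percentage points higher (within the scatter) from compound 1 to compound 2 and a number 4.6 percentage points lower (within the scatter) from compound 3 to compound 4, 6.1 percentage points apart, within the scatter of two such steps

The other change, 4-methoxyphenyl in place of 2,4-dichlorophenyl, gave a number 8.2 percentage points lower from compound 2 to compound 4 (within the scatter), and it likewise agrees with its earlier counterpart: the same change on two cores in this assay, a number 2.1 percentage points lower (within the scatter) from compound 1 to compound 3 and a number 8.2 percentage points lower (within the scatter) from compound 2 to compound 4, 6.1 percentage points apart, within the scatter of two such steps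

So nothing here argues against carrying either change from one core to the other, but since every step lies within the scatter, this does not show that either change has any effect, or that its effect is truly the same on both cores.

The compounds shown compare only fluoro and chloro at this place, so it remains open how an amine, a carboxylic acid or a longer chain there would read in this assay. Also open, going by these compounds, is whether any change can move the number beyond the scatter, and whether these small differences at a single dose would hold at other doses.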